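The compounds below may be only part of what the source reports. "The series", "measured", "known", "first", "only" and "open" are said of these compounds alone.

Compound 2 `COc1ccc(/C(Cl)=C/C=C(\C#N)C(=O)c2c[nH]c3ccccc23)cc1OC` carries the shared core without any methyl on it. In an ADME assay on Vero cells (Chlorocebus sabaeus) for cytotoxicity, read by sulforhodamine B assay, with a stated time of 48 h (a lower number here means a stronger inhibitor of growth, a higher number a weaker inhibitor of growth), compound 2 gives "not determined" (no result reported), so it stands without a single number. Compound 1 `COc1ccc(/C(Cl)=C/C=C(\C#N)C(=O)c2c(C)[nH]c3ccccc23)cc1` likewise gives "not determined" (no result reported) in this assay, leaving it also without a figure. Only compound 3 `COc1ccc(/C(Cl)=C/C=C(\C#N)C(=O)c2c[nH]c3ccc(Br)cc23)cc1OC` provides one: in this assay compound 3 gives 8200 nM. Compound 4 `COc1ccc(/C(Cl)=C/C=C(\C#N)C(=O)c2c(C)[nH]c3ccccc23)cc1OC` differs from compound 2 by methyl in place of hydrogen on an aromatic carbon. Among the compounds with values here, no measured pair shows what this change does in this assay, so the step from compound 2 to compound 4 is expected to stay within the usual scatter, with no clear direction. Taking compound 3 as the sole anchor, compound 4 is estimated at 9000 nM in this assay, with a range from 3000 nM to 30000 nM.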

Compound 4, concentration for 50% growth inhibition: 11800 nM
The estimate for compound 4 lay 1.3-fold (0.12 log units) below the measured number, and the stated range covers the measured number.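

Within the data shown here, compound 2 has no single number in this assay, so no step from it to compound 4 can be read. What methyl in place of hydrogen does in this assay stays open, and nothing shown bears on a cause for the value of compound 4.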